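The source may hold more compounds than are shown below. What is called first, only, known or untested is meant among the compounds shown, and "the series" means these compounds.

Results in a functional assay on THP-1 cells (Homo sapiens) for inhibition, read by sulforhodamine B assay, with a stated time of 48 h, tested at 50 uM; a lower number here means less inhibition of growth, a higher number more inhibition of growth at the concentration tested:
- compound 1 `COc1cc(/C=C/C(=O)/C=C/c2ccco2)ccc1OCc1cn(CCCOc2cc(=O)oc3ccccc23)nn1`: 57%
- compound 2 `COc1ccc(/C=C/C(=O)/C=C/c2ccc(OCc3cn(CCCOc4cc(=O)oc5ccccc45)nn3)c(OC)c2)cc1OC`: 73%
- compound 3 `COc1ccc(/C=C/C(=O)/C=C/c2ccc(OCc3cn(CCOc4cc(=O)oc5ccccc45)nn3)c(OC)c2)cc1`: 78%

Compound 2 lies within the usual scatter of compound 3 and clearly above compound 1. Compound 4 `COc1cc(/C=C/C(=O)/C=C/c2cccs2)ccc1OCc1cn(CCCOc2cc(=O)oc3ccccc23)nn1` is the next case, and it changes compound 2 as follows: thiophen-2-yl in place of 3,4-dimethoxyphenyl on a double-bonded chain carbon bound to a double-bonded chain carbon. The measured step that bears on this is a number 16 percentage points higher from compound 1 to compound 2 (beyond the scatter), where 3,4-dimethoxyphenyl replaced furan-2-yl at the same place. Compound 4 also carries a five-membered aromatic ring with 1 hetero atom there, so a fall of similar size is expected, towards compound 1 at 57%. The expected change is a number 13 percentage points lower from compound 2 to compound 4 (beyond the scatter). For compound 4 the estimate is 60%, with an expected range of 47% to 73%.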

Compound 4, percent growth inhibition at one concentration: 54%
The estimate for compound 4 lay 6 percentage points above the measured number; low and high end bracket the measured number.
By their numbers in this assay, from the lowest: compounds 4 and 1 (each within the scatter of the next); then compounds 2 and 3 (each within the scatter of the next).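

Swapping one five-membered ring for the other gives a number 3 percentage points lower from compound 1 to compound 4 (within the scatter), so furan-2-yl and thiophen-2-yl cannot be told apart at this place on the chain. By contrast, the replacement of 3,4-dimethoxyphenyl is a clear change, with a number 19 percentage points lower from compound 2 to compound 4 (beyond the scatter), so the step seen with furan-2-yl is not unique to that ring. No available evidence explains this difference.

The compounds shown leave open whether the gap follows the six-membered aromatic ring itself or its two methoxy groups. An unsubstituted phenyl at this place would separate the two.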